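This account rests on a few compounds, and the source may have more. Where it says the series, first, only, none or still open, it means among the compounds named here.

Among the measured compounds shown here, in a functional assay with Alpha-1D adrenergic receptor (Homo sapiens) as the target, read by calcium flux (a higher number here means a larger maximal response, a lower number a smaller maximal response), compound 1 `CCCn1ncnc1-c1ccccc1NCC1=NCCN1` gives 57%, while compound 2 `CC(C)n1ncnc1-c1ccccc1NCC1=NCCN1` gives 37%, the lower of the two numbers measured so far. For the measured compounds named here, the only measured step, a number 20 percentage points lower from compound 1 to compound 2 (beyond the scatter), was isopropyl in place of propyl on an aromatic nitrogen. Compound 3 `CCn1ncnc1-c1ccccc1NCC1=NCCN1` differs from compound 2 by hydrogen in place of methyl on a saturated chain carbon bound to an aromatic nitrogen and a saturated chain carbon. Going by the values given here, that single step is all that bears on this change, and it moved toward a smaller response when the chain was branched; trimming the branched chain to ethyl has no direct counterpart, so the expected step of a number 13 percentage points higher from compound 2 to compound 3 (beyond the scatter) carries wide uncertainty. Compound 3 is expected to give about 50%, plausibly between 30% and 70%.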

Compound 3, largest response reached (reported as maximal response), in percent of the reference or control that the assay uses: 55%
Estimate against measurement, compound 3: 5 percentage points below; the measured number falls inside the stated range.
By their numbers in this assay, from the lowest: compound 2; then compounds 3 and 1 (each within the scatter of the next).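

In this assay, taking one methyl off the isopropyl group gives a number 18 percentage points higher from compound 2 to compound 3 (beyond the scatter), so the lower response of compound 2 does not simply follow from having a chain of a different length. The two straight chains, propyl and ethyl, give a number 2 percentage points lower from compound 1 to compound 3 (within the scatter) and cannot be told apart, which leaves the branched isopropyl of compound 2 as the only one of the three to stand apart. Nothing available explains this difference. Going by these compounds, how a butyl chain or a cyclopropyl ring on this aromatic nitrogen would compare remains open.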